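Changing the aryl group of compound 2: a halogen swap

The source may hold more compounds than are shown below. What is called first, only, known or untested is meant among the compounds shown, and "the series" means these compounds.

compound 1 `COc1ccc(/C=N/NC(=S)N/N=C2\C(=O)Nc3ccc(C)cc32)cc1O` gives 3190 nM
compound 2 `O=C1Nc2ccc(Br)cc2/C1=N/NC(=S)N/N=C/c1ccc(Br)cc1` gives 5180 nM
compound 3 `O=C1Nc2ccc(Br)cc2/C1=N/NC(=S)N/N=C/c1ccc2ccccc2c1` gives a limit, > 50000 nM

In a functional assay on COS-7 cells (Chlorocebus aethiops) for inhibition, read by MTT assay (on this read-out lower numbers stand for stronger inhibition and higher numbers for weaker inhibition), compound 2 stands at the highest of the two plain numbers, with compound 1 close enough that the two lie within the scatter of the method. For compound 3 only a limit is known, (the limit of > 50000 nM in this assay, at which 1 of the 3 values shown sits). Compound 4 `O=C1Nc2ccc(Br)cc2/C1=N/NC(=S)N/N=C/c1c(Cl)cccc1Cl` is not yet measured; it differs from compound 2 in one place: 2,6-dichlorophenyl in place of 4-bromophenyl on a carbon with a double bond to nitrogen. Among the compounds with values here, no measured pair with a comparable change is available, so the expected step is small, in either direction or none beyond the scatter. Compound 4 is therefore estimated at 6000 nM, between 2000 nM and 25000 nM, which amounts to an expected step of a 1.2-fold higher number from compound 2 to compound 4 (0.06 log units; within the scatter) in this assay.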

Compound 4, half-maximal inhibitory concentration: 6730 nM
Beside the measured number, compound 4's estimate is 1.1-fold (0.05 log units) below it; low and high end bracket the measured number.
By their numbers in this assay, from the lowest: compounds 1, 2 and 4 (each within the scatter of the next, the first and the last beyond it). At a limit, above all of these: compound 3.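

In this assay, 2,6-dichlorophenyl in place of 4-bromophenyl gives a 1.3-fold higher number from compound 2 to compound 4 (0.11 log units; within the scatter). This position on the carbon with a double bond to nitrogen therefore accepts a phenyl ring with two chlorine atoms instead of one bromine without a change that can be told from the scatter. Nothing measured here bears on why these two groups read alike.

Still open, as far as these compounds go, is how this position would respond to a phenyl ring carrying an amine or a carboxylic acid. From the compounds shown here alone, for compound 3, > 50000 nM is a limit, so its distance from the others remains unknown.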